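From Carbamoyl to Trifluoromethoxy: An Expected Rise

This account rests on a few compounds, and the source may have more. Where it says the series, first, only, none or still open, it means among the compounds named here.

In a physicochemical assay for solubility, at pH 7.4 (on this read-out higher numbers stand for higher solubility and lower numbers for lower solubility), compound 2 (`Cc1cc(NC(=O)Nc2cccc(C(N)=O)c2)c2ccccc2n1`) gives 100 nM, level with compound 3 (`Cc1cc(NC(=O)Nc2ccccc2C(C)(C)C)c2ccccc2n1`) at 100 nM. Together they form the low end of the three measured compounds, while compound 1 (`Cc1cc(NC(=O)Nc2ccccc2OC(F)(F)F)c2ccccc2n1`) gives 4600 nM.

The next compound changes one group. Compound 4 (`Cc1cc(NC(=O)Nc2cccc(OC(F)(F)F)c2)c2ccccc2n1`) carries trifluoromethoxy in place of carbamoyl on an aromatic carbon, meta to a large group: trifluoromethoxy in place of carbamoyl on an aromatic carbon.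

Within the data shown here, no measured step makes this exact swap. The closest evidence is the step that puts tert-butyl in place of trifluoromethoxy on an aromatic carbon, which gives a 46-fold lower number from compound 1 to compound 3 (1.66 log units; beyond the scatter). Among the measured compounds shown here, that large step suggests that a trifluoromethoxy compound can read high, but compound 1 at 4600 nM is the only measured example, and its step did not involve carbamoyl. It is therefore a loose guide, and only part of its size is carried over. The expected result in this assay is a rise, an estimated 7.0-fold higher number from compound 2 to compound 4 (0.85 log units; beyond the scatter). For compound 4 the estimate is 700 nM, with an expected range from 150 nM to 4000 nM.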

Compound 4, solubility: 600 nM
Beside the measured number, compound 4's estimate is 1.2-fold (0.07 log units) above it; measured number inside the range.
By their numbers in this assay, from the lowest: compounds 2 and 3 (each within the scatter of the next); then compound 4; then compound 1.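

In this assay, the exchange of carbamoyl for trifluoromethoxy on this aromatic carbon, meta to a large group, now has a direct reading: a 6.0-fold higher number from compound 2 to compound 4 (0.78 log units; beyond the scatter). Among these compounds, until this pair, the only step involving trifluoromethoxy had been its exchange for tert-butyl, so this is the first step to show what happens when carbamoyl leaves, and it is beyond the usual scatter. The two groups differ in what is counted, with 1 hydrogen-bond donor in carbamoyl and 0 in trifluoromethoxy, but no measurement shown explains the rise.

This remains a single exchange at a single place on the ring, so it cannot show whether the same step would appear elsewhere on that ring. It also leaves open how other groups at this position, such as an amine or a carboxylic acid, would read.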